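Removing One Methyl from Compound 2

A few compounds are considered here, and "the series" means these few. Any claim that something is new, unique, unknown or untested is made for them only; others in the source may bear on it.

Compound 1 `COC(=O)C1=C(C)N=C(C)/C(=C(\O)OC)C1c1ccc(I)cc1`: 22900 nM
Compound 2 `COC(=O)C1=C(C)N=C(C)/C(=C(\O)OC)C1c1cc(C)ccc1C`: 100 nM

Among the compounds with values here, in a functional assay (muscle tissue) with Cavia porcellus as the target (a higher number here means that more compound is needed for the effect, a lower number that less compound is needed), compound 2 gives 100 nM, the lower of the two numbers measured so far, and compound 1 lies well above it. Compound 3 `COC(=O)C1=C(C)N=C(C)/C(=C(\O)OC)C1c1ccccc1C` has not yet been measured. It differs from compound 2 by hydrogen in place of methyl on an aromatic carbon, turning 2,5-dimethylphenyl into 2-methylphenyl. Within the data shown here, only one measured step bears on this change, a 230-fold lower number from compound 1 to compound 2 (2.36 log units; beyond the scatter). That step is large, but it exchanges a different group, so it gives no direct measure of what a single methyl contributes. A much smaller move toward a higher number in this assay is therefore expected, and it may stay close to the scatter. The estimated change is a 2.2-fold higher number from compound 2 to compound 3 (0.34 log units; beyond the scatter). Compound 3 is expected at 220 nM, with an estimated range of 40 nM to 1200 nM.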

Compound 3, half-maximal effective concentration: 6.03 nM
Compound 3: the middle estimate sits 36-fold (1.56 log units) above what was measured; the whole stated range lies above it.
By their numbers in this assay, from the lowest: compound 3; then compound 2; then compound 1.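

In this assay, a single methyl on the aromatic carbon para to a methyl group proves to count heavily: hydrogen in its place gives a 17-fold lower number from compound 2 to compound 3 (1.22 log units; beyond the scatter) and turns 2,5-dimethylphenyl into 2-methylphenyl. The earlier step exchanged the whole aryl group, whereas this one isolates that methyl and shows that adding it to 2-methylphenyl raises the number rather than lowering it. Measured against 4-iodophenyl, 2-methylphenyl gives a 3800-fold lower number from compound 1 to compound 3 (3.58 log units; beyond the scatter) and leaves compound 3 with the lowest number of the three. Nothing available explains why this methyl has so large an effect.

Going by these compounds, what the remaining methyl contributes stays open, as does what a plain phenyl would give. So does the effect of a methoxy group or a chlorine atom on the carbon that now carries hydrogen.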